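Compound 4 and a Series Held at a Limit

The source may hold more compounds than are shown below. What is called first, only, known or untested is meant among the compounds shown, and "the series" means these compounds.

Measured in a toxicity assay on THP-1 cells (Homo sapiens) for inhibition (on this read-out lower numbers stand for higher toxicity in this test and higher numbers for lower toxicity in this test), so far:
Compound 1 `COc1ccc(-c2cnc(NC(=O)c3ccccc3O)n2C)cc1` gives > 100000 nM as a limit
Compound 2 `COc1ccc(-c2cnc(NC(=O)c3cnc[nH]3)n2C)cc1` gives > 100000 nM as a limit
Compound 3 `COc1ccc(-c2cnc(NC(=O)c3ccco3)n2C)cc1` gives > 100000 nM as a limit

For compound 3 the value > 100000 nM is a limit and not a number. Its standing is thus the limit of > 100000 nM in this assay, at which 3 of the 3 values shown sit, and no rank can be read from it. Compound 4 `COc1ccc(-c2cnc(NC(=O)c3ccccc3C#N)n2C)cc1` carries 2-cyanophenyl in place of furan-2-yl on a carbonyl carbon, a change counted as 2-cyanophenyl in place of furan-2-yl on a carbonyl carbon and not yet measured. Bearing on it are a step that the two limits leave unreadable from compound 1 to compound 3 and a step that the two limits leave unreadable from compound 2 to compound 3 and a step that the two limits leave unreadable from compound 1 to compound 2 with no size to read from any. Compound 1 carries 2-hydroxyphenyl and gives > 100000 nM as a limit. No step beyond the scatter is therefore expected in this assay and no direction is favoured. The expected size is a number no higher from compound 3 to compound 4 (the limit leaves the size open) in this estimate. Compound 4 is estimated at 100000 nM with an expected range from 40000 nM to 250000 nM and most likely only a limit again.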

Compound 4, half-maximal cytotoxic concentration: > 100000 nM
Compound 4: no number, only a limit; the forecaster's own chance of this, stated with the estimate: 85%; the middle value sits exactly at the limit.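

No step from compound 1, compound 2 or compound 3 to compound 4 can be read, as all of them stand at one limit: the limit of > 100000 nM in this assay, at which 4 of the 4 values shown sit.

The compounds shown leave open whether any group on the carbonyl carbon would give a number rather than a limit in this assay.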